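This account rests on a few compounds, and the source may have more. Where it says the series, first, only, none or still open, it means among the compounds named here.

Three compounds share one core, and the point where they differ is the amine attached to a carbonyl carbon on a short chain. Compound 1 `CC(C)(C)OC(=O)NCCCCNC(=O)CN1CN(c2ccccc2)C2(CCN(C(=O)c3ccc(C(C)(C)C)cc3)CC2)C1=O` carries a protected four-carbon diamine there, and in an assay on HEK293 cells for displacement of a labelled ligand from NPC1-like intracellular cholesterol transporter 1 (Homo sapiens) (on this read-out lower numbers stand for stronger inhibition and higher numbers for weaker inhibition), compound 1 gives "not determined" (no result reported), so no number is known for it. Compound 2 `CC(C)(C)c1ccc(C(=O)N2CCC3(CC2)C(=O)N(CC(=O)NCCN)CN3c2ccccc2)cc1` carries a free (2-aminoethyl)amino group, and in this assay compound 2 gives 7000 nM. Compound 3 `CCC1CCCN(C(=O)CN2CN(c3ccccc3)C3(CCN(C(=O)c4ccc(C(C)(C)C)cc4)CC3)C2=O)C1` carries a 3-ethylpiperidin-1-yl group, and in this assay compound 3 gives 3900 nM. Among the two numbers known, compound 3 holds the lower one, but the step of a 1.8-fold lower number from compound 2 to compound 3 (0.25 log units; within the scatter) stays within the scatter, so the two cannot be told apart.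

Compound 4 `CC(C)(C)c1ccc(C(=O)N2CCC3(CC2)C(=O)N(CC(=O)NCCCCCO)CN3c2ccccc2)cc1` differs from compound 3 by (5-hydroxypentyl)amino in place of 3-ethylpiperidin-1-yl on a carbonyl carbon. For the measured compounds named here, the only step that bears on this change is the one from compound 2 to compound 3, which exchanged an open-chain amine for the same ring amine without leaving the scatter. The change from compound 3 to compound 4 runs back towards an open-chain amine, now with a hydroxyl end, so in this assay compound 4 is expected to give 5500 nM, between 2000 nM and 15000 nM, an expected step of a 1.4-fold higher number from compound 3 to compound 4 (0.15 log units; within the scatter).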

Compound 4, half-maximal inhibitory concentration: 9400 nM
The estimate for compound 4 lay 1.7-fold (0.23 log units) below the measured number; the range from low to high includes it.
By their numbers in this assay, from the lowest: compounds 3, 2 and 4 (each within the scatter of the next, the first and the last beyond it).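

In this assay, this position now gives a step that leaves the scatter, though only a modest one: a 2.4-fold higher number from compound 3 to compound 4 (0.38 log units; beyond the scatter) when the 3-ethylpiperidin-1-yl group is replaced by (5-hydroxypentyl)amino. The two open-chain amines cannot be told apart, with a 1.3-fold higher number from compound 2 to compound 4 (0.13 log units; within the scatter) staying within the scatter, so the hydroxyl-ended chain and the shorter amino-ended chain give matching results. The ring amine of compound 3 therefore stands apart from compound 4, but not from compound 2.

The compounds shown leave open how a ring amine without the ethyl group, a longer chain or a carboxylic acid at the chain end would read out at this position. Nothing available explains why the step from compound 3 to compound 4 has this size.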